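Isopropyl to tert-butyl on the aryl amide series

This account rests on a few compounds, and the source may have more. Where it says the series, first, only, none or still open, it means among the compounds named here.

In an ADME assay on HEp-2 cells (Homo sapiens) for cytotoxicity (a higher number here means that more compound is tolerated, a lower number that less compound is tolerated), compound 1 (`Cc1ccc(C)c(NC(=O)[C@@H]2CCCN2S(=O)(=O)c2cccc3cccnc23)c1`) gives 30900 nM and compound 2 (`Cc1ccc(C(C)C)cc1NC(=O)[C@@H]1CCCN1S(=O)(=O)c1cccc2cccnc12`) gives 9700 nM as the lower of the two numbers. Compound 3 (`Cc1ccc(C(C)(C)C)cc1NC(=O)[C@@H]1CCCN1S(=O)(=O)c1cccc2cccnc12`) follows from compound 2 by methyl in place of hydrogen on a saturated chain carbon bound to an aromatic carbon and two saturated chain carbons in the form of methyl in place of hydrogen on a saturated chain carbon bound to an aromatic carbon and two saturated chain carbons, which reads as isopropyl to tert-butyl. For the measured compounds named here, the single measured step bearing on this is a 3.2-fold lower number from compound 1 to compound 2 (0.50 log units; beyond the scatter) for isopropyl in place of methyl on an aromatic carbon. A small move to a lower number in this assay is expected, the estimated change being a 1.8-fold lower number from compound 2 to compound 3 (0.25 log units; within the scatter) on this one precedent alone. Compound 3 is estimated at 5500 nM within a range of 2400 nM to 12000 nM on this reading.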

Compound 3, half-maximal cytotoxic concentration: 6500 nM
Beside the measured number, compound 3's estimate is 1.2-fold (0.07 log units) below it; measured number inside the range.
By their numbers in this assay, from the lowest: compounds 3 and 2 (each within the scatter of the next); then compound 1.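

Going from isopropyl to tert-butyl gives a 1.5-fold lower number from compound 2 to compound 3 (0.17 log units; within the scatter) in this assay, so the added methyl on this saturated chain carbon produces no separation that can be read. Measured against methyl on the aromatic carbon, tert-butyl gives a 4.8-fold lower number from compound 1 to compound 3 (0.68 log units; beyond the scatter), which places both branched groups on the same side of compound 1. Nothing available here accounts for this result.

Still open, from the compounds shown here alone, is how a carboxylic acid, an amine or a longer chain on this aromatic carbon would read in this assay. The methyl, isopropyl and tert-butyl groups alone do not show whether the number would stay near that of compound 3 with such groups.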